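The compounds below may be only part of what the source reports. "The series", "measured", "known", "first", "only" and "open" are said of these compounds alone.

Compounds measured in a physicochemical assay for lipophilicity, using the shake flask method, in phosphate buffer, measured as octanol-water partition, with a stated time of 24 h, at pH 7.4, tested at 100 uM; on this read-out higher numbers stand for higher lipophilicity and lower numbers for lower lipophilicity:
- compound 1 `Cc1cccc(C)c1-c1cccc(COc2ccc(S(=O)(=O)CC(=O)O)cc2)c1`: 2.49
- compound 2 `Cc1ccccc1-c1cccc(COc2ccc(S(=O)(=O)CC(=O)O)cc2)c1`: 2.35
- compound 3 `COc1ccccc1-c1cccc(COc2ccc(S(=O)(=O)CC(=O)O)cc2)c1`: "not determined" (no result reported)

As far as these compounds go, compound 3 has no number on this scale, so any step away from it remains unknown. Compound 4 `Cc1ccc(-c2cccc(COc3ccc(S(=O)(=O)CC(=O)O)cc3)c2)c(Cl)c1`, still to be measured in this assay, carries 2-chloro-4-methylphenyl in place of 2-methoxyphenyl on an aromatic carbon.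

Among the measured compounds shown here, only one measured step is available, a number 0.14 log units lower from compound 1 to compound 2 (within the scatter). It is hydrogen in place of methyl on an aromatic carbon, so it bears on the methyl of the entering group and only loosely. For the measured compounds named here, no measured step covers the chlorine or the loss of the methoxy group. With compound 3 offering no starting point, the expectation rests on compound 1 at 2.49 and compound 2 at 2.35. No direction can be given from compound 3, and compound 4 is expected to stay close to these two values, with a wide range for the unmeasured chlorine. For compound 4 the estimated value is 2.6, with an expected range of 2.2 to 3.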

Compound 4, distribution coefficient: 3.05
For compound 4 the middle estimate is 0.45 log units below the measured one; measured number outside the range, above it.
By their numbers in this assay, from the lowest: compounds 2 and 1 (each within the scatter of the next); then compound 4.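

Among the compounds shown here, until now, the only measured change on this aromatic carbon, meta to a large group, stayed within the scatter, whereas in this assay 2-chloro-4-methylphenyl in place of 2-methylphenyl gives a number 0.70 log units higher from compound 2 to compound 4 (beyond the scatter) and in place of 2,6-dimethylphenyl gives a number 0.56 log units higher from compound 1 to compound 4 (beyond the scatter) so that this position can carry a change beyond the scatter. Compound 3 has no number in this assay so the exchange of its 2-methoxyphenyl for 2-chloro-4-methylphenyl cannot be read. No measurement at hand accounts for these steps.

The compounds shown do not separate the share of the chlorine from that of the second methyl, since both change together in each step. They also leave open how a fluorine, a trifluoromethyl or a nitrile in the chlorine's place would read on this scale.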